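A few compounds are considered here, and "the series" means these few. Any claim that something is new, unique, unknown or untested is made for them only; others in the source may bear on it.

Compound 3 `N#CC1=C(N)Oc2c(N)cc3nc4ccccc4nc3c2C12C(=O)N(Cc1cnnn1-c1ccccc1Cl)c1ccccc12` is the starting point. For the measured compounds named here, in a functional assay on MCF7 cells (Homo sapiens) for antiproliferative activity, read by MTT assay, with a stated time of 48 h (a lower number here means a stronger inhibitor, a higher number a weaker inhibitor), compound 3 gives 34400 nM, the only plain number among the three measured compounds, and a weak result in itself. Compound 1 `N#CC1=C(N)Oc2c(c3nc4ccccc4nc3c3ccccc23)C12C(=O)N(Cc1cnnn1-c1ccccc1Cl)c1ccccc12` gives > 50000 nM in this assay, which is a limit of the assay and not a number. Compound 2 `N#CC1=C(N)Oc2c(c3nc4ccccc4nc3c3ccccc23)C12C(=O)N(Cc1cnnn1-c1ccc(S(N)(=O)=O)cc1)c1ccccc12` likewise gives > 50000 nM in this assay, again a limit rather than a number. The step that the two limits leave unreadable from compound 1 to compound 2 cannot be read because of the limit of > 50000 nM in this assay, at which 2 of the 3 values shown sit. Compound 4 `CCc1cccc(CC)c1-n1nncc1CN1C(=O)C2(C(C#N)=C(N)Oc3c(N)cc4nc5ccccc5nc4c32)c2ccccc21` has not yet been measured. It differs from compound 3 in one place: 2,6-diethylphenyl in place of 2-chlorophenyl on an aromatic nitrogen. Going by the values given here, the only measured step at this aromatic nitrogen is the unreadable one, so no measured step tells how large a change at this position is, in either direction. Compound 4 is therefore expected to give 35000 nM in this assay, with a range from 15000 nM to 80000 nM. The expected step is a 1.0-fold higher number from compound 3 to compound 4 (0.01 log units; within the scatter), no larger than the usual scatter.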

Compound 4, half-maximal inhibitory concentration: > 50000 nM
Compound 4 gave a limit, no number; the forecaster's own chance of this, stated with the estimate: 40%; at least 1.4-fold (0.15 log units) between middle value and limit.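

In this assay compound 4 gives > 50000 nM as a limit of the assay and not a number. Swapping 2-chlorophenyl for the larger 2,6-diethylphenyl gives an at least 1.4-fold higher number from compound 3 to compound 4 (0.16 log units; that floor lies within the scatter) and so offers the first floor for a step at this aromatic nitrogen, showing no gain but no loss beyond the scatter either. The real size of this step and the step between compound 1 and compound 2 cannot be read, because so many values sit at one limit: the limit of > 50000 nM in this assay, at which 3 of the 4 values shown sit.

From the compounds shown here alone, it remains open whether a plain phenyl or a phenyl carrying an amine or a carboxylic acid on this nitrogen would lower the number given by compound 3. Going by these compounds, a methyl or a longer alkyl chain in place of the aromatic ring is equally open.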